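This account rests on a few compounds, and the source may have more. Where it says the series, first, only, none or still open, it means among the compounds named here.

Measured so far:
compound 1, `COc1cc(-c2cc(/C=C/C(=O)c3ccc(N)cc3)[nH]n2)cc(OC)c1OC` — 91%
compound 2, `COc1ccc(-c2cc(/C=C/C(=O)c3ccc(N)cc3)[nH]n2)cc1OC` — 99%
compound 3, `COc1ccc(-c2cc(/C=C/C(=O)c3cc(OC)c(OC)c(OC)c3)[nH]n2)cc1OC` — 82%

Series notes. In a functional assay on UO-31 cells (Homo sapiens) for cytotoxicity, read by sulforhodamine B assay, with a stated time of 48 h, tested at 0.1 uM (on this read-out lower numbers stand for a stronger effect and higher numbers for a weaker effect at the one concentration tested), compound 1 gives 91% and stands second highest of the three numbers; its nearest neighbour is compound 2, whose value lies within the scatter of it, and the furthest is compound 3, also within the scatter. For the measured compounds named here, the one single-place step, a number 8 percentage points higher from compound 1 to compound 2 (within the scatter), concerns a methoxy on the aromatic ring of the shared core and says nothing directly about the carbonyl-attached ring. Compound 2 and compound 3 differ at that ring; in this assay compound 2 gives 99% and compound 3 gives 82%, and the two values lie within the scatter of each other.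

Compound 4, `COc1cc(-c2cc(/C=C/C(=O)c3ccc(F)c(F)c3)[nH]n2)cc(OC)c1OC`, is not yet measured. It differs from compound 1 as follows: 3,4-difluorophenyl in place of 4-aminophenyl on a carbonyl carbon. Going by the values given here, no measured step covers this change. Among the compounds with values here, all three numbers so far lie within one scatter band, so for compound 4 no step beyond the scatter is expected in this assay, and the estimated step is a number 3 percentage points lower from compound 1 to compound 4 (within the scatter). Compound 4 is thus expected to give about 88%, in the range 72% to 102%.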

Compound 4, a percentage reported as activity, at one concentration (the size of the read-out at that concentration, not a potency): 86%
Compound 4: the middle estimate sits 2 percentage points above what was measured, within the range that was stated.
By their numbers in this assay, from the lowest: compounds 3, 4, 1 and 2 (each within the scatter of the next, the first and the last beyond it).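

In this assay, the position on the carbonyl carbon now has its first direct single-place reading: a number 5 percentage points lower from compound 1 to compound 4 (within the scatter) for 3,4-difluorophenyl in place of 4-aminophenyl. The hydrogen-bond donor and acceptor counted on 4-aminophenyl are absent from 3,4-difluorophenyl, and at this one concentration that exchange gives no step beyond the scatter. No measurement is at hand that could explain this result.

Whether the same exchange reads alike on the core of compound 2 remains open, as that pair is not among the compounds shown. Also open, going by these compounds, is whether another group on the carbonyl carbon, such as 4-hydroxyphenyl, a pyridyl ring or a phenyl ring bearing a carboxylic acid, would give a step beyond the scatter from compound 1.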